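Swapping a Bromophenyl for Pyridine on the Benzyl Ether

A few compounds are considered here, and "the series" means these few. Any claim that something is new, unique, unknown or untested is made for them only; others in the source may bear on it.

Compound 1 `Cc1c(C2CC2)nc2ccc(-n3ccc(OCc4ccc(Br)cc4)cc3=O)cn12` was tested in an assay on CHO cells for displacement of a labelled ligand from melanin-concentrating hormone receptor 1 (Homo sapiens), read by scintillation counting, with a stated time of 1 h (a lower number here means a stronger inhibitor, a higher number a weaker inhibitor), and gives 12 nM, the lowest of the two numbers reported. Compound 2 `CCc1nc2ccc(-n3ccc(OCc4ccccc4)cc3=O)cn2c1C` gives 120 nM in this assay, a higher number that lies beyond the usual scatter. Compound 3 `COCc1nc2ccc(-n3ccc(OCc4ccc(F)cc4)cc3=O)cn2c1C` gives > 1000 nM, which is a limit of the assay rather than a number. Compound 4 `Cc1c(C2CC2)nc2ccc(-n3ccc(OCc4cccnc4)cc3=O)cn12` is not yet measured. It differs from compound 1 in one place: pyridin-3-yl in place of 4-bromophenyl on a saturated chain carbon bound to an oxygen on an aromatic ring. Going by the values given here, no measured pair isolates this change; compound 2 and compound 1 differ in more than one place, so their two values give only a hint. The step from compound 1 to compound 4 is expected to be a 17-fold higher number from compound 1 to compound 4 (1.22 log units; beyond the scatter), towards a weaker inhibitor. Compound 4 is estimated at 200 nM, within 50 nM to 1000 nM.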

Compound 4, half-maximal inhibitory concentration: > 1000 nM
Compound 4 ended at the assay's limit; the forecaster's own chance of this, stated with the estimate: 20%; at least 5.0-fold (0.69 log units) between middle value and limit.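

Going by these compounds alone, this is the first single change read at this place: with the rest of compound 1 kept, pyridin-3-yl in place of 4-bromophenyl gives an at least 83-fold higher number from compound 1 to compound 4 (1.92 log units; beyond the scatter) in this assay. Activity at this receptor therefore depends strongly on the ring carried by the benzyl ether position, and swapping one six-membered aromatic ring for another is not a neutral change. The true size of the step stays unknown because the value of compound 4 is a limit, not a number: the limit of > 1000 nM in this assay, at which 2 of the 4 values shown sit.

This single swap cannot show whether losing the bromine or gaining the ring nitrogen matters more. On these data alone, how a 4-chlorophenyl or a pyridin-2-yl would behave at this place on the same core remains open.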